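The compounds below may be only part of what the source reports. "The series", "measured", "known", "first", "only" and "open" are said of these compounds alone.

Measured so far in a functional assay on MDA-MB-468 cells (Homo sapiens) for antiproliferative activity, read by MTT assay, with a stated time of 72 h; a higher number here means a weaker inhibitor, a lower number a stronger inhibitor:
Compound 1 `CCn1ccnc1-c1cc(OC)c(OC)c(OC)c1`: > 100000 nM, a limit.
Compound 2 `CCCCn1ccnc1-c1cc(OC)c(OC)c(OC)c1`: 44100 nM.
Compound 3 `COc1cc(-c2nccn2Cc2ccccc2)cc(OC)c1OC`: > 100000 nM, a limit.

Compound 3 has no number, only the limit > 100000 nM. The series shows (the limit of > 100000 nM in this assay, at which 2 of the 3 values shown sit).

Compound 4 `COc1cc(-c2nccn2-c2ccc(F)cc2)cc(OC)c1OC` carries 4-fluorophenyl in place of benzyl on an aromatic nitrogen.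

Going by the values given here, no measured step makes this exact change. The nearest steps alter the chain on that same nitrogen. They are an at least 2.2-fold lower number from compound 1 to compound 2 (0.35 log units; beyond the scatter) and an at least 2.2-fold higher number from compound 2 to compound 3 (0.35 log units; beyond the scatter), while a step that the two limits leave unreadable from compound 1 to compound 3 cannot be sized. Among the compounds with values here, compound 2, at 44100 nM, is the only member with a number, so the group on this nitrogen can bring a compound within the measurable range. A modest move toward a lower number in this assay is therefore expected, with a real chance that the result stays at the limit. The expected step is an at least 3.3-fold lower number from compound 3 to compound 4 (0.52 log units; beyond the scatter). For compound 4 the estimated value is 30000 nM, with an expected range of 4000 nM to 100000 nM.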

Compound 4, half-maximal inhibitory concentration: 62200 nM
Compound 4: middle estimate off by 2.1-fold (0.32 log units), on the low side, and the stated range covers the measured number.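

In this assay compound 4 is the second member with a number, so a ring bound directly to this nitrogen reaches the measurable range as the butyl chain does, and a 1.4-fold higher number from compound 2 to compound 4 (0.15 log units; within the scatter) leaves 4-fluorophenyl and butyl indistinguishable. Against the other two groups, the readings an at least 1.6-fold lower number from compound 3 to compound 4 (0.20 log units; that floor lies within the scatter) and an at least 1.6-fold lower number from compound 1 to compound 4 (0.20 log units; that floor lies within the scatter) give only floors, and these do not clear the scatter. Going by these compounds, their true size stays unknown because the partner compounds are not numbers but limits: the limit of > 100000 nM in this assay, at which 2 of the 4 values shown sit.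

Whether the fluorine contributes anything of its own stays open, since unsubstituted phenyl on this nitrogen is not among the compounds shown. Also open, on these data alone, is whether a longer chain such as hexyl, or a chain ending in an amine, would move the number beyond the scatter from that of compound 2.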